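A few compounds are considered here, and "the series" means these few. Any claim that something is new, unique, unknown or untested is made for them only; others in the source may bear on it.

Measured compounds in an ADME assay on NIH3T3 cells (Mus musculus) for cytotoxicity, read by CCK-8 assay, with a stated time of 24 h; on this read-out higher numbers stand for weaker inhibition and lower numbers for stronger inhibition:

Compound 1 `C/C(=C\c1cc(-c2ccc(C)cc2)co1)C(N)=O` gives > 50000 nM, which is a limit of the assay rather than a number.
Compound 2 `C/C(=C\c1cc(-c2ccc(C)cc2)cs1)C(N)=O` gives > 50000 nM, again a limit of the assay.
Compound 3 `C/C(=C\c1cc(-c2ccc(C#N)cc2)cs1)C(N)=O` gives > 50000 nM, also a limit of the assay.

Compound 3 therefore stands where every measured compound stands, at the limit of > 50000 nM in this assay, at which 3 of the 3 values shown sit, and no number separates it from compound 1 or compound 2. Among the compounds with values here, the one measured step that changes a single place, a step that the two limits leave unreadable from compound 2 to compound 3, cannot be read in size because both of its ends are limits. Compound 4 `C/C(=C\c1cc(-c2ccc(C(F)(F)F)cc2)cs1)C(N)=O` differs from compound 3 by trifluoromethyl in place of cyano on an aromatic carbon. Within the data shown here, no measured step bears on this exact change, and the one step available gives no readable size, so the only guide is that all three compounds sit at the limit. In this assay no step beyond the usual scatter is expected from compound 3 to compound 4, and the likeliest outcome is once more a limit rather than a number. Compound 4 is therefore estimated at 60000 nM, within a range from 20000 nM to 200000 nM. The expected step that the limit leaves unreadable from compound 3 to compound 4 is accordingly small.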

Compound 4, half-maximal inhibitory concentration: > 50000 nM
Compound 4: a limit, no number (the forecaster's own chance of this, stated with the estimate: 85%); the middle value does not contradict the limit.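

Compound 4 gives a limit rather than a number, as do compound 2 and compound 3, so no step among these three can be read in size. The compounds shown leave open whether methyl, cyano and trifluoromethyl differ at all in cytotoxicity, because every result is a limit: the limit of > 50000 nM in this assay, at which 4 of the 4 values shown sit.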